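The source may hold more compounds than are shown below. What is called first, only, known or untested is meant among the compounds shown, and "the series" means these compounds.

Going by the values given here, in a functional assay on KB cells (Homo sapiens) for antiproliferative activity, read by sulforhodamine B assay, with a stated time of 3 days (a lower number here means that less compound is needed, a higher number that more compound is needed for the effect), compound 3 `CCC1=C(O)c2c(oc(-c3ccc(OC)c(C)c3)cc2=O)C(CC)(CC)C1=O` gives 28.5 uM, the only exact number among the measured compounds. Compound 1 `CCC1=C(O)c2c(oc(-c3cccc(F)c3)cc2=O)C(CC)(CC)C1=O` gives > 56.2 uM, which is a limit. Compound 2 `CCC1=C(O)c2c(oc(-c3ccccc3F)cc2=O)C(CC)(CC)C1=O` gives > 56.2 uM, also a limit. The other readings therefore sit at the limit of > 56.2 uM in this assay, at which 2 of the 3 values shown sit.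

Compound 4 `CCC1=C(O)c2c(oc(-c3cc(C)cc(C)c3)cc2=O)C(CC)(CC)C1=O` carries 3,5-dimethylphenyl in place of the 4-methoxy-3-methylphenyl of compound 3, on an aromatic carbon next to the ring oxygen: 3,5-dimethylphenyl in place of 4-methoxy-3-methylphenyl on an aromatic carbon. Among the compounds with values here, the steps that bear on this change are an at least 1.9-fold lower number from compound 1 to compound 3 (0.29 log units; that floor lies within the scatter) and an at least 1.9-fold lower number from compound 2 to compound 3 (0.29 log units; that floor lies within the scatter). Both have only a floor, and that floor lies within the scatter. The step that the two limits leave unreadable from compound 1 to compound 2 adds no size. None of these steps isolates the exchange made in compound 4, so no step beyond the scatter is expected in this assay, and neither direction is favoured. The expected result is a 1.1-fold higher number from compound 3 to compound 4 (0.02 log units; within the scatter). For compound 4 the estimated value is 30 uM, with an expected range of 12 uM to 56 uM.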

Compound 4, concentration for half-maximal effect: 45.5 uM
Compound 4: the middle estimate sits 1.5-fold (0.18 log units) below what was measured; measured number inside the range.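

In this assay, putting 3,5-dimethylphenyl, which has no hydrogen-bond acceptor, in place of 4-methoxy-3-methylphenyl next to the ring oxygen gives a 1.6-fold higher number from compound 3 to compound 4 (0.20 log units; within the scatter), so this exchange of two aryl groups produces no step beyond the scatter. The comparisons with the fluorophenyl groups give only floors, namely an at least 1.2-fold lower number from compound 2 to compound 4 (0.09 log units; that floor lies within the scatter) and an at least 1.2-fold lower number from compound 1 to compound 4 (0.09 log units; that floor lies within the scatter), so they do not separate these groups from 3,5-dimethylphenyl. The values of compound 1 and compound 2 are limits, not numbers: the limit of > 56.2 uM in this assay, at which 2 of the 4 values shown sit.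

The compounds shown leave open whether an amine or a carboxylic acid on this phenyl ring would move the number beyond the scatter. They also leave open what a smaller group such as methyl, in place of the phenyl ring at this position, would do.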